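The source may report more compounds than this note shows. Statements on the series, on what has been measured and on what is new or still open speak of the compounds shown alone.

Among the compounds with values here, in an assay on isolated protein for inhibition of long-chain fatty acid transport protein 1 (Homo sapiens) (on this read-out lower numbers stand for stronger inhibition and higher numbers for weaker inhibition), compound 2 `CC/C(=N/O)c1ccc2oc(CSc3nnc(CNc4ccccc4)n3CC)nc2c1` gives 260 nM, the only number recorded there. Compound 1 `CCn1c(CNc2ccccc2)nnc1SCc1nc2cc(F)ccc2o1` in this assay reaches only a limit, giving > 1000 nM. Within the data shown here, the single measured step, an at least 3.8-fold lower number from compound 1 to compound 2 (0.58 log units; beyond the scatter), is the one change that has been followed, and its size is bounded by the limit (the limit of > 1000 nM in this assay, at which 1 of the 2 values shown sits). Compound 3 `CCn1c(CNc2ccccc2)nnc1SCc1nc2cc(OC(F)(F)F)ccc2o1` differs from compound 2 by a group of 5 heavy atoms (1 carbon, 1 oxygen, 3 fluorine; no ring) in place of a group of 5 heavy atoms (3 carbon, 1 nitrogen, 1 oxygen; no ring), on an aromatic carbon. Compound 3 thus moves back toward the small substituent of compound 1, and a step of at least the measured size is expected, in the weakening direction. Compound 3 is therefore expected to shift by a 5.0-fold higher number from compound 2 to compound 3 (0.70 log units; beyond the scatter) to an estimated 1300 nM, between 400 nM and 4500 nM.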

Compound 3, half-maximal inhibitory concentration: 100 nM
Estimate against measurement, compound 3: 13-fold (1.11 log units) above; measured number below the stated range.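

In this assay, this aromatic carbon accepts a group with no hydrogen-bond donor: with trifluoromethoxy there is a 2.6-fold lower number from compound 2 to compound 3 (0.41 log units; beyond the scatter), so the donor and double bond of the group in compound 2 are not required for a low number. Both groups count the same number of heavy atoms, so that count alone does not set the result, while trifluoromethoxy in place of fluoro gives an at least 10-fold lower number from compound 1 to compound 3 (1.00 log units; beyond the scatter). Compound 1 is a limit, so this step is bounded on one side only: the limit of > 1000 nM in this assay, at which 1 of the 3 values shown sits.

The compounds shown leave open how an amine or a carboxylic acid on this aromatic carbon would read in this assay.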